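Chalcone series: alkoxy chain variation at the aryl ether

This account rests on a few compounds, and the source may have more. Where it says the series, first, only, none or still open, it means among the compounds named here.

Working notes on a small set of chalcone-type compounds measured in a functional assay on NCI-H23 cells (Homo sapiens) for antiproliferative activity, read by sulforhodamine B assay; on this read-out higher numbers stand for weaker inhibition of growth and lower numbers for stronger inhibition of growth.

Compound 1 `CC(C)=CCOc1cccc(O)c1C(=O)/C=C/c1ccc(O)cc1` carries a 3-methylbut-2-en-1-yl ether on its core. In this assay compound 1 gives > 30000 nM, which is a limit of the assay and not a number. Compound 2 `CC(C)(C)CCOc1cccc(O)c1C(=O)CCc1ccc(O)cc1`, a saturated analogue with a different chain, also gives > 30000 nM in this assay, again a limit rather than a measured number. So compound 1 stands at the top of what the assay reports, and there is no measured spread in this set at all: the limit of > 30000 nM in this assay, at which 2 of the 2 values shown sit, describes everything known so far.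

For the measured compounds named here, no step between measured compounds can be counted here. Compound 3 `O=C(/C=C/c1ccc(O)cc1)c1c(O)cccc1OCCC1CCCCC1` differs from compound 1 by cyclohexylmethyl in place of 2-methylprop-1-en-1-yl on a saturated chain carbon bound to an oxygen on an aromatic ring. With both known compounds at the limit, there is no measured basis for any direction, and the step from compound 1 to compound 3 is expected to be a step that the limit leaves unreadable from compound 1 to compound 3, meaning none that can be resolved beyond the scatter. Compound 3 is therefore estimated at 40000 nM, within a range of 15000 nM to 150000 nM, most likely reported as a limit again.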

Compound 3, concentration for 50% growth inhibition: > 30000 nM
Compound 3 was reported as a limit; the forecaster's own chance of this, stated with the estimate: 75%; the middle value lies beyond the limit too.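

No step can be read between compound 1 and compound 3 in this assay, as both are reported only as limits of the assay and not as numbers: the limit of > 30000 nM in this assay, at which 3 of the 3 values shown sit.

The compounds shown leave open whether any chain on the ether oxygen of the shared core gives a measurable value in this assay.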